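The source may hold more compounds than are shown below. What is called first, only, known or untested is meant among the compounds shown, and "the series" means these compounds.

Compound 1 `Cc1nc(-c2ccc(C(F)(F)F)cc2)sc1CNc1ccc(C(=O)O)cc1` — < 10000 nM in a functional assay on CHO cells for agonist activity at Free fatty acid receptor 1 (Homo sapiens) (on this read-out lower numbers stand for an effect already at smaller amounts and higher numbers for an effect only at larger amounts of compound), a limit only
Compound 2 `O=C(O)COc1ccc(NCc2cccc(Oc3ccccc3)c2)cc1` — 2040 nM
Compound 3 `O=C(O)[C@H]1C[C@@H]1c1ccc(NCc2cccc(Oc3ccccc3)c2)cc1` — 12.3 nM; 13.5 nM (2 entries)

Compound 1 is the only one of the three for which this assay gives no number: its result of < 10000 nM is a limit of the assay, so the compound cannot be placed against the others on a scale. Among the compounds with values here, compound 2 and compound 3 share a core different from that of compound 1, and no single-point step joins either of them to compound 1; what their two values show is that compound 3, at 12.3 nM; 13.5 nM (2 entries), sits far lower than compound 2, which gives 2040 nM, the readings for compound 3 being reproducible (the several entries of compound 3 in this assay, 12.3 nM; 13.5 nM (2 entries)).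

The unmeasured compound 4 `Cc1nc(-c2ccc(C(F)(F)F)cc2)sc1CNc1ccc([C@H]2C[C@@H]2C(=O)NO)cc1` keeps the core of compound 1 and differs from it in one place: 2-(hydroxycarbamoyl)cyclopropyl in place of carboxy on an aromatic carbon. Within the data shown here, since compound 1 stands only at a limit (the limit of < 10000 nM in this assay, at which 1 of the 3 values shown sits), no measured step can anchor the size of this change. Compound 4 is therefore expected to land in the mid-nanomolar to low-micromolar region, with a wide uncertainty, the step from compound 1 being a step that the limit leaves unreadable from compound 1 to compound 4 in direction of an effect at smaller amounts. The estimated value of compound 4 in this assay is 600 nM, spanning 60 nM to 6000 nM.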

Compound 4, half-maximal effective concentration: 6.92 nM
For compound 4 the middle estimate is 87-fold (1.94 log units) above the measured one; measured number below the stated range.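

In this assay compound 1 gives only a limit, < 10000 nM, so the change from compound 1 to compound 4 cannot be read as a step of any size. The compounds shown leave open how the three-membered ring and the hydroxycarbamoyl part of 2-(hydroxycarbamoyl)cyclopropyl each relate to the value of compound 4.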